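The compounds below may be only part of what the source reports. "The series", "measured", "known", "first", "only" and "open" are said of these compounds alone.

Measured in a functional assay on A549 cells (Homo sapiens) for cytotoxicity, read by MTT assay, with a stated time of 24 h, tested at 80 uM; a lower number here means a stronger effect, a higher number a weaker effect of the compound at the concentration tested:
compound 1 `CCCOC(=O)CCC(=O)N1CCN(CCCOc2cc3c(Nc4ccc(F)c(Cl)c4)ncnc3cc2OC)CC1`: 23.4%
compound 2 `CCCCCCOC(=O)CCC(=O)N1CCN(CCCOc2cc3c(Nc4ccc(F)c(Cl)c4)ncnc3cc2OC)CC1`: 42.9%
compound 3 `CCCCCCCCCCCCCCOC(=O)CCC(=O)N1CCN(CCCOc2cc3c(Nc4ccc(F)c(Cl)c4)ncnc3cc2OC)CC1`: 77.2%

Compound 3 gives the highest of the three numbers, with compound 2 nearest to it and compound 1 furthest. The unmeasured compound 4 `CCCCCCCCCCCCCCCCCCCCOC(=O)CCC(=O)N1CCN(CCCOc2cc3c(Nc4ccc(F)c(Cl)c4)ncnc3cc2OC)CC1` differs from compound 3 by hexyl in place of hydrogen on a saturated chain carbon, ten or more bonds along the chain from an oxygen next to a carbonyl group. All three measured steps bear on this change and run the same way: a number 19.5 percentage points higher from compound 1 to compound 2 (beyond the scatter), a number 34.3 percentage points higher from compound 2 to compound 3 (beyond the scatter) and a number 53.8 percentage points higher from compound 1 to compound 3 (beyond the scatter). Each lengthening of this chain has so far raised the number beyond the scatter. A further step of the same kind in this assay is therefore expected upward, though the room above compound 3 is limited, so a moderate rise is expected, a number 10.8 percentage points higher from compound 3 to compound 4 (beyond the scatter). Compound 4 is estimated at 88%, between 74% and 100%.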

Compound 4, a percentage reported as activity, at one concentration (the size of the read-out at that concentration, not a potency): 85.2%
Compound 4: the middle estimate sits 2.8 percentage points above what was measured; the measured number falls inside the stated range.
By their numbers in this assay, from the lowest: compound 1; then compound 2; then compounds 3 and 4 (each within the scatter of the next).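

In this assay, among the compounds shown here, hexyl in place of hydrogen on this saturated chain carbon gives a number 8 percentage points higher from compound 3 to compound 4 (within the scatter) and is the first step that stays inside the scatter. The climb with chain length that holds from compound 1 through compound 3 is therefore not resolved beyond compound 3, and compound 3 and compound 4 cannot be told apart in this read-out. No available evidence explains this step.

Going by these compounds, whether a longer chain would stay level remains open. So does the effect of an amine or a carboxylic acid carried on this chain.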